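Changing the acid chain of compound 1

This account rests on a few compounds, and the source may have more. Where it says the series, first, only, none or still open, it means among the compounds named here.

- compound 1 `CCCCC1([C@@H](O)/C=C/C2[C@H](O)CC(=O)[C@@H]2CCCCCCC(=O)O)CCC1` gives 0.0439 mg/kg
- compound 2 `CCCCC1([C@@H](O)/C=C/C2CCC(=O)[C@@H]2CCCCCCC(=O)O)CCC1` gives 0.0203 mg/kg
- compound 3 `CCCCC1([C@H](O)/C=C/C2CCC(=O)[C@@H]2CCCCCC(=O)O)CCC1` gives 0.032 mg/kg

These values come from a functional assay on the whole organism (strain Hartley) for inhibition, with Cavia porcellus as the target, with stated times of 15 min and 2 min; on this read-out lower numbers stand for an effect already at smaller amounts and higher numbers for an effect only at larger amounts of compound. Compound 1 stands at the high end of this small set. Compound 3 lies within the usual scatter of it, while compound 2 lies beyond that scatter.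

The next compound, compound 4 `CCCCC1([C@@H](O)/C=C/C2[C@H](O)CC(=O)[C@@H]2C/C=C\CCCC(=O)O)CCC1`, alters only the acid chain of compound 1: 5-carboxypent-1-en-1-yl in place of 5-carboxypentyl on a saturated chain carbon bound to a saturated ring carbon. Here 5-carboxypent-1-en-1-yl comes in place of 5-carboxypentyl on a saturated chain carbon bound to a saturated ring carbon.

Among the measured compounds shown here, no measured step touches this chain alone. For the measured compounds named here, the one clean step, a 2.2-fold lower number from compound 1 to compound 2 (0.33 log units; beyond the scatter), put hydrogen in place of hydroxy on a saturated ring carbon, so it is only a loose guide to how far a single change can move the number. Going by the values given here, compound 3 differs from compound 1 in more than one place and gives no clean step.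

In this assay, no shift beyond the scatter is therefore expected, in either direction. The expected change is a 1.1-fold lower number from compound 1 to compound 4 (0.04 log units; within the scatter). For compound 4 the estimated value is 0.04 mg/kg, with an expected range of 0.015 mg/kg to 0.11 mg/kg.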

Compound 4, dose for half-maximal effect: 0.305 mg/kg
Beside the measured number, compound 4's estimate is 7.6-fold (0.88 log units) below it; measured number above the stated range.
By their numbers in this assay, from the lowest: compounds 2, 3 and 1 (each within the scatter of the next, the first and the last beyond it); then compound 4.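

The acid chain proves to be a sensitive place in this assay: 5-carboxypent-1-en-1-yl in place of 5-carboxypentyl gives a 6.9-fold higher number from compound 1 to compound 4 (0.84 log units; beyond the scatter). Among the compounds shown here, the two chains have the same count of heavy atoms and differ by one double bond, yet this step is larger than the only other clean step, a 2.2-fold lower number from compound 1 to compound 2 (0.33 log units; beyond the scatter), where hydrogen replaces hydroxy on a saturated ring carbon. For the compounds shown here, nothing available explains why this small change in the chain moves the number so far.

As far as these compounds go, it remains open whether hydrogen in place of that ring hydroxy would lower the number for compound 4 as it does for compound 1. From the compounds shown here alone, it is equally open how a triple bond in the chain, or a methyl ester in place of the carboxylic acid, would read.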